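Working notes on the step from compound 2 to compound 4

The source may hold more compounds than are shown below. What is called first, only, known or untested is meant among the compounds shown, and "the series" means these compounds.

Three compounds carry measurements in an assay on cells for inhibition of Amine oxidase [flavin-containing] A (Homo sapiens), read by fluorescence and spectrophotometry, using microsomes, with a stated time of 20 min; on this read-out lower numbers stand for stronger inhibition and higher numbers for weaker inhibition. Compound 1 `NS(=O)(=O)c1cccc(-c2nnc(-c3ccc(Cl)cc3)o2)c1` returns only a limit in this assay, > 100000 nM, and not a number. Compound 2 `NS(=O)(=O)c1ccc(C(=O)NNC(=O)c2ccccc2)cc1` gives 62800 nM in this assay. Compound 3 `NS(=O)(=O)c1ccc(-c2nnc(-c3ccccc3)o2)cc1` gives 63900 nM in this assay. Compound 2 thus holds the lower of the two numbers available, but compound 3 sits within the scatter of it, so the two cannot be placed in order; both sit at the weak end of the range covered by this assay.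

Compound 4 `N#Cc1ccc(C(=O)NNC(=O)c2ccc(S(N)(=O)=O)cc2)cc1` differs from compound 2 by cyano in place of hydrogen on an aromatic carbon. For the measured compounds named here, no pair of measured compounds in this set differs in a single place, so the size of this step has no measured anchor here. The expectation for this assay is a step that stays within the scatter, with at most a slight lean toward a lower number. Compound 4 is expected to give 45000 nM in this assay, within a range from 15000 nM to 140000 nM. The estimated step from compound 2 to compound 4 is therefore a 1.4-fold lower number from compound 2 to compound 4 (0.14 log units; within the scatter).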

Compound 4, half-maximal inhibitory concentration: 16100 nM
The estimate for compound 4 lay 2.8-fold (0.45 log units) above the measured number; measured number inside the range.
By their numbers in this assay, from the lowest: compound 4; then compounds 2 and 3 (each within the scatter of the next). At a limit, above all of these: compound 1.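

Cyano in place of hydrogen, on an aromatic carbon para to a large group, gives a 3.9-fold lower number from compound 2 to compound 4 (0.59 log units; beyond the scatter). For the compounds shown here, this is the first step that can be read at all, and it shows that this end of compound 2 responds to substitution: phenyl to 4-cyanophenyl moves the number beyond the scatter, though only modestly. Going by these compounds alone, compound 1 remains the one compound held at a limit and not at a number, and it takes no part in this step: the limit of > 100000 nM in this assay, at which 1 of the 4 values shown sits.

Going by these compounds, with a single step on hand, it remains open whether this shift belongs to cyano specifically or would also follow from another group at this place, such as an amine, a methoxy group or a carboxylic acid. On these data alone, it also remains open whether the same change would carry over to the core of compound 3.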